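The compounds below may be only part of what the source reports. "The series", "measured", "known", "first", "only" and "open" are said of these compounds alone.

Of the compounds shown here, three of a shared core have been measured in a functional assay on HeLa cells (Homo sapiens) for antiproliferative activity, with a stated time of 24 h; on this read-out higher numbers stand for weaker inhibition and lower numbers for stronger inhibition. Compound 1 `Cc1ccccc1CN1CCc2c(sc(NC(=O)c3ccccc3Cl)c2C(N)=O)C1` reaches only a limit of the assay, > 50000 nM, rather than a number. Compound 2 `NC(=O)c1c(NC(=O)c2ccccc2Cl)sc2c1CCN(Cc1ccccc1F)C2` likewise reports a limit, > 50000 nM. Going by the values given here, compound 3 `NC(=O)c1c(NC(=O)c2ccccc2Cl)sc2c1CCN(C(=S)Nc1ccccc1)C2` is the one compound with a number: in this assay compound 3 gives 46700 nM. Among the compounds with values here, compound 3 therefore stands as the only readable value among the three, with the other two resting at the limit of the assay. The step of an at least 1.0-fold lower number from compound 1 to compound 3 (0.02 log units; that floor lies within the scatter) and the step of an at least 1.0-fold lower number from compound 2 to compound 3 (0.02 log units; that floor lies within the scatter) are each only a floor, and a step that the two limits leave unreadable from compound 1 to compound 2.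

Compound 4 `NC(=O)c1c(NC(=O)c2ccccc2Cl)sc2c1CCN(C(=O)Nc1c(Cl)cccc1Cl)C2` is not yet measured. It differs from compound 3 in this way: a group of 11 heavy atoms (7 carbon, 1 nitrogen, 1 oxygen, 2 chlorine; one six-membered aromatic ring of carbon only) in place of a group of 9 heavy atoms (7 carbon, 1 nitrogen, 1 sulfur; one six-membered aromatic ring of carbon only), on an amine nitrogen in a ring. The measured steps that bear on this change are those onto the same amine nitrogen in a ring, and both give no more than a floor within the scatter, so they offer no direction. The estimate for compound 4 therefore expects little movement beyond the scatter, a step of a 1.2-fold lower number from compound 3 to compound 4 (0.07 log units; within the scatter). In this assay compound 4 is expected to give about 40000 nM, within a range from 12000 nM to 120000 nM.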

Compound 4, half-maximal inhibitory concentration: 27200 nM
For compound 4 the middle estimate is 1.5-fold (0.17 log units) above the measured one; the measured number falls inside the stated range.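

The exchange of the group on this amine nitrogen in a ring for (2,6-dichlorophenyl)carbamoyl gives the first step at this position in this assay with a number at both ends, a 1.7-fold lower number from compound 3 to compound 4 (0.23 log units; within the scatter), so swapping the sulfur-bearing group for this carbamoyl group is not shown to move the read-out. Against the benzyl groups only floors can be given, an at least 1.8-fold lower number from compound 2 to compound 4 (0.26 log units; that floor lies within the scatter) and an at least 1.8-fold lower number from compound 1 to compound 4 (0.26 log units; that floor lies within the scatter), so (2,6-dichlorophenyl)carbamoyl is not shown to differ beyond the scatter from 2-fluorobenzyl or 2-methylbenzyl. Compound 1 and compound 2 each rest on a limit of the assay rather than a number: the limit of > 50000 nM in this assay, at which 2 of the 4 values shown sit.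

The single step from compound 3 to compound 4 changes sulfur to oxygen and also brings in two chlorine atoms, and the compounds shown leave open what each change contributes, which a phenylcarbamoyl group without chlorine would help to separate. As far as these compounds go, it also remains open whether any group on this nitrogen, such as a carboxylic acid or a longer chain, moves the number beyond the scatter.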